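Alkyl chain swap on a potent series

This account rests on a few compounds, and the source may have more. Where it says the series, first, only, none or still open, it means among the compounds named here.

Values so far in a functional assay on MDA-MB-231 cells (Homo sapiens) for antiproliferative activity, with a stated time of 4 days; a lower number here means a stronger inhibitor, a higher number a weaker inhibitor

- compound 1 `COc1ccc(-c2[nH]c3cc(F)ccc3c2C=O)cc1` at 59 nM
- compound 2 `COc1ccc(-c2[nH]c3cc(Cl)ccc3c2C=O)cc1` at 27 nM
- compound 3 `COc1ccc(-c2[nH]c3ccc(C(C)C)cc3c2C=O)cc1` at 29 nM

Compound 3 (29 nM) cannot be told apart from compound 2 (27 nM), while compound 1 (59 nM) shows a higher number beyond the scatter. Compound 4 (`CCCCCc1ccc2[nH]c(-c3ccc(OC)cc3)c(C=O)c2c1`) carries pentyl in place of isopropyl on an aromatic carbon. Among the compounds with values here, no measured step exchanges one alkyl chain for another. Within the data shown here, the only step available (a 2.2-fold lower number from compound 1 to compound 2 (0.34 log units; beyond the scatter)) is chloro in place of fluoro, so it bears only indirectly. Among the measured compounds shown here, a step of similar modest size is expected in this assay, tentatively toward a higher number, although no measured step settles the direction. Compound 4 is expected at 60 nM (range 20 nM to 180 nM) on this reasoning. The expected size is a 2.1-fold higher number from compound 3 to compound 4 (0.32 log units; beyond the scatter) and remains an estimate.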

Compound 4, half-maximal inhibitory concentration: 5.5 nM
For compound 4 the middle estimate is 11-fold (1.04 log units) above the measured one, outside the stated range (below it).
By their numbers in this assay, from the lowest: compound 4; then compounds 2 and 3 (each within the scatter of the next); then compound 1.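

In this assay, within the data shown here, pentyl in place of isopropyl gives a 5.3-fold lower number from compound 3 to compound 4 (0.72 log units; beyond the scatter) and so shows what the earlier compounds could not: the number responds to the alkyl chain on this aromatic carbon. The position accepts the longer pentyl chain with a gain, not a loss, as an inhibitor. No measurement at hand accounts for this step. On these data alone, whether a longer chain such as heptyl would lower the number further remains open. So does whether a cyclohexyl ring or a terminal amine on the chain would keep the gain.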